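The source may hold more compounds than are shown below. What is called first, only, known or untested is meant among the compounds shown, and "the series" means these compounds.

Of the compounds shown here, two have so far been measured in a physicochemical assay for lipophilicity, measured as octanol-water partition; on this read-out higher numbers stand for higher lipophilicity and lower numbers for lower lipophilicity. Compound 1 (`C/C(CC(=O)Nc1nnc(-c2ccc(O)cc2)s1)=N\c1ccc([N+](=O)[O-])cn1`) gives 3.34 and compound 2 (`C/C(CC(=O)Nc1nnc(-c2ccc(O)cc2)s1)=N\c1ccccn1`) gives 3.43 on this scale, so the two numbers lie within the scatter of each other. Compound 3 (`C/C(CC(=O)Nc1nnc(-c2ccc(N)cc2)s1)=N\c1ccccn1`) differs from compound 2 at one place (amino in place of hydroxy on an aromatic carbon), with amino in place of hydroxy on an aromatic carbon, which turns 4-hydroxyphenyl into 4-aminophenyl. Within the data shown here, only one measured step is available (a number 0.09 log units higher from compound 1 to compound 2 (within the scatter)), and it stays within the scatter. That step, hydrogen in place of nitro on an aromatic carbon, lies elsewhere in the structure and does not touch the hydroxy group, so it offers only indirect guidance. Among the measured compounds shown here, no measured pair shows this exchange itself. The step expected in this assay is therefore small and slightly downward (a number 0.18 log units lower from compound 2 to compound 3 (within the scatter)), with none anticipated beyond the scatter. For compound 3 the estimated value is 3.25 with an expected range from 2.8 to 3.65 as its likely span.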

Compound 3, partition coefficient: 3.3
The estimate for compound 3 lay 0.05 log units below the measured number; low and high end bracket the measured number.
By their numbers in this assay, from the lowest: compounds 3, 1 and 2 (each within the scatter of the next).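

In this assay, the exchange of 4-hydroxyphenyl for 4-aminophenyl gives a number 0.13 log units lower from compound 2 to compound 3 (within the scatter) with the rest of the structure unchanged. The earlier step concerned hydrogen and nitro elsewhere in the structure, whereas this one shows that a change on an aromatic carbon of the six-membered carbon ring, para to a large group, also stays within the scatter; hydroxy and amino each count one heavy atom, one hydrogen-bond donor and one hydrogen-bond acceptor, so the comparison involves no difference in those counts. Nothing available here offers an explanation for this outcome.

The compounds shown leave open whether this position would stay as insensitive with a different kind of group, such as a methoxy group, a carboxylic acid or a chlorine atom, since only hydroxy and amino have been compared there. Among these compounds, they also leave open whether the exchange of hydroxy for amino would give a similar step on a structure carrying the nitro group of compound 1, as no such pair is available.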